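A few compounds are considered here, and "the series" means these few. Any claim that something is new, unique, unknown or untested is made for them only; others in the source may bear on it.

Compound 1 `Cc1cc(S(=O)(=O)/N=C(\N)n2nccc2-c2ccccc2)c(SCc2ccccc2)cc1Cl` was tested in a functional assay on HeLa cells (Homo sapiens) for cytotoxicity, read by MTT assay, with a stated time of 72 h (a lower number here means a stronger inhibitor, a higher number a weaker inhibitor), where compound 1 gives 5000 nM. Two close relatives frame this number. Compound 3 `Cc1cc(-c2ccccc2)n(/C(N)=N/S(=O)(=O)c2cc(C)c(Cl)cc2SCc2ccccc2)n1` carries an extra methyl on its core and gives 5000 nM; the step of no change at the digits printed from compound 1 to compound 3 (within the scatter) shows the two compounds sitting together. Compound 2 `Cc1cccc(CSc2cc(Cl)c(C)cc2S(=O)(=O)/N=C(\N)n2nc(C)cc2-c2ccccc2)c1` carries yet another methyl, this time on the benzyl ring, and gives 155000 nM; the step of a 31-fold lower number from compound 2 to compound 3 (1.49 log units; beyond the scatter) is large. On these numbers compound 1 stands level with compound 3, the two lowest of the three values, and far from compound 2.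

Compound 4 `Cc1cc(S(=O)(=O)/N=C(\N)n2nccc2-c2ccccc2)c(SCc2ccc(Cl)cc2)cc1Cl` has not yet been measured. It differs from compound 1 in one place: chloro in place of hydrogen on an aromatic carbon, turning the benzyl group into a 4-chlorobenzyl group. Within the data shown here, no measured step speaks to a chloro in this position. The step from compound 2 to compound 3 concerns a methyl on the benzyl ring rather than a chloro, and the step from compound 1 to compound 3 concerns the core, so neither gives firm direction. Without a bearing step, compound 4 is expected to stay near compound 1, with a step of no change at the digits printed from compound 1 to compound 4 (within the scatter). Compound 4 is therefore estimated at 5000 nM, within a range from 1600 nM to 16000 nM.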

Compound 4, half-maximal inhibitory concentration: 3000 nM
Compound 4: middle estimate off by 1.7-fold (0.22 log units), on the high side, within the range that was stated.
By their numbers in this assay, from the lowest: compounds 4, 1 and 3 (each within the scatter of the next); then compound 2.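

In this assay, among these compounds, the step of a 1.7-fold lower number from compound 1 to compound 4 (0.22 log units; within the scatter) gives a reading for a chloro on the benzyl ring of the benzylsulfanyl group, whereas the earlier steps concerned only methyl groups. Turning benzyl into 4-chlorobenzyl adds one chlorine atom on an aromatic carbon, para to a large group, and the number stays within the usual scatter, so in this assay the position tolerates a chloro with no measurable gain or loss. The data offered here contain nothing that explains this result.

As far as these compounds go, whether this tolerance extends to other groups at the same position, such as a methoxy group, an amine or a carboxylic acid, remains open, since a single chlorine atom says little about groups of a different kind. Also open, from the compounds shown here alone, is whether the 4-chlorobenzyl group would give the same reading on the core of compound 3, which carries the extra methyl, and whether any replacement here can move the number beyond the scatter at all.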